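The compounds below may be only part of what the source reports. "The series", "measured", "known", "first", "only" and "open" are said of these compounds alone.

Working notes on the series. Going by the values given here, compound 1 `CCc1ccc(NC(=O)Nc2cc(C)nc3ccccc23)cc1` and compound 2 `Cc1cc(NC(=O)Nc2cccc(C(N)=O)c2)c2ccccc2n1` carry the shared core and are the only compounds with a result so far. In an ADME assay on Raji cells (Homo sapiens) for cytotoxicity, with a stated time of 72 h (a higher number here means that more compound is needed for the effect, a lower number that less compound is needed), compound 1 gives > 25000 nM, which is a limit and not a number. In this assay compound 2 gives > 25000 nM, which is also a limit. Among the compounds with values here, compound 2 therefore has no numerical value and stands only at that limit, and no step between measured compounds is available.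

The next compound is compound 3 `COC(=O)c1cccc(NC(=O)Nc2cc(C)nc3ccccc23)c1`. It has methoxy in place of amino on a carbonyl carbon, which reads as carbamoyl to methoxycarbonyl: methoxy in place of amino on a carbonyl carbon.

For this assay the expectation is no change beyond the scatter, in either direction. This expectation rests only on the results so far, (the limit of > 25000 nM in this assay, at which 2 of the 2 values shown sit). The expected step is a number no higher from compound 2 to compound 3 (the limit leaves the size open). For compound 3 the estimated value is 25000 nM, with an expected range of 10000 nM to 50000 nM. A report of only a limit is the expected form of the result.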

Compound 3, half-maximal effective concentration: 26000 nM
Compound 3: middle estimate off by 1.0-fold (0.02 log units), on the low side, within the range that was stated.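

In this assay compound 2 gives > 25000 nM, which is a limit and not a number. Compound 3 gives 26000 nM. No step can be read from compound 2 to compound 3. The compounds shown leave open whether methoxy in place of amino on a carbonyl carbon changes the result in this assay at all.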